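The compounds below may be only part of what the source reports. "The series", "measured", "known", "first", "only" and "open" are said of these compounds alone.

Among the measured compounds shown here, in an ADME assay on L6 cells (Rattus norvegicus) for cytotoxicity, read by fluorescence, with a stated time of 72 h (on this read-out higher numbers stand for weaker inhibition and lower numbers for stronger inhibition), compound 1 `CN1CCN(C23CCN(CCCN4CCCCC4)C(C(c4ccccc4)C2)C(c2ccccc2)C3)CC1` gives 28900 nM and compound 2 `CN1CCN(C23CC(NC(=O)CN4CCCC4)C(C(c4ccccc4)C2)C(c2ccccc2)C3)CC1` gives 27800 nM as its value, so compound 2 stands within the scatter of the only other measured compound. Compound 3 `CCN(CC)CCC(=O)NC1CC2(N3CCN(C)CC3)CC(c3ccccc3)C1C(c1ccccc1)C2` is still unmeasured. The change from compound 2 to compound 3 is (diethylamino)methyl in place of pyrrolidin-1-yl on a saturated chain carbon bound to a carbonyl carbon and amounts to (diethylamino)methyl in place of pyrrolidin-1-yl on a saturated chain carbon bound to a carbonyl carbon. Cut one bond further out, it reads (pyrrolidin-1-yl)methyl to 2-(diethylamino)ethyl. For the measured compounds named here, no measured pair differs in one place only, so no step size in this assay can be read directly. With compound 2 at 27800 nM as the anchor, no step beyond the scatter is expected in either direction. The expected step of a 1.2-fold lower number from compound 2 to compound 3 (0.06 log units; within the scatter) is accordingly small. For compound 3 the estimated value is 24000 nM with an expected range from 11000 nM to 50000 nM in this measurement.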

Compound 3, half-maximal inhibitory concentration: 35900 nM
The estimate for compound 3 lay 1.5-fold (0.17 log units) below the measured number, and the stated range covers the measured number.
By their numbers in this assay, from the lowest: compounds 2, 1 and 3 (each within the scatter of the next).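

In this assay, among the compounds shown here, the swap to (diethylamino)methyl in place of pyrrolidin-1-yl on a saturated chain carbon bound to a carbonyl carbon gives a 1.3-fold higher number from compound 2 to compound 3 (0.11 log units; within the scatter), the first step that can be read at one place. At this place, then, an open-chain amine and the ring of pyrrolidin-1-yl stand within the scatter of each other, and the two groups carry the same counts of hydrogen-bond donors and acceptors. No measurement at hand bears on the reason for the size of this step.

As far as these compounds go, whether a morpholin-4-yl group, a carboxylic acid or a longer chain at this place would give a step beyond the scatter stays open. Steps from compound 1 to the other two compounds cannot be read, since it differs from them in more than one place.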